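Nitro on the fused ring of compound 1

The source may report more compounds than this note shows. Statements on the series, on what has been measured and on what is new or still open speak of the compounds shown alone.

Compound 1 `NS(=O)(=O)c1cccc(/N=C2\NC(=O)/C(=C3/C(=O)Nc4ccccc43)S2)c1` gives 12100 nM in a functional assay on Caco-2 cells (Homo sapiens) for antiproliferative activity, read by MTT assay (on this read-out lower numbers stand for stronger inhibition and higher numbers for weaker inhibition), the lowest of the numbers shown. Compound 2 `NS(=O)(=O)c1cccc(/N=C2\NC(=O)/C(=C3/C(=O)N(Cc4ccccc4)c4ccccc43)S2)c1` gives 103000 nM, and compound 3 `Cc1cc(C)c2c(c1)/C(=C1/S/C(=N/c3ccc(S(N)(=O)=O)cc3)NC1=O)C(=O)N2` gives 146000 nM. The only single-point step among these is an 8.5-fold higher number from compound 1 to compound 2 (0.93 log units; beyond the scatter); compound 3 differs from compound 1 in two places, so its weaker number can only be noted, not assigned to either change.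

Compound 4 `NS(=O)(=O)c1cccc(/N=C2\NC(=O)/C(=C3/C(=O)Nc4ccc([N+](=O)[O-])cc43)S2)c1` differs from compound 1 as follows: nitro in place of hydrogen on an aromatic carbon. Within the data shown here, no measured step touches the fused ring alone. Compound 3 carries methyl groups on that ring and is weak, but it also moves the sulfonamide, so it gives no clean guidance. The step from compound 1 to compound 2 shows the core tolerates substitution poorly at the amide nitrogen, yet that is a different position. A small loss or no change beyond the scatter is therefore the most defensible expectation, and the account estimates a 1.7-fold higher number from compound 1 to compound 4 (0.22 log units; within the scatter). Compound 4 is expected to give about 20000 nM, within 7000 nM to 60000 nM.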

Compound 4, half-maximal inhibitory concentration: 20600 nM
Beside the measured number, compound 4's estimate is 1.0-fold (0.01 log units) below it; measured number inside the range.
By their numbers in this assay, from the lowest: compounds 1 and 4 (each within the scatter of the next); then compounds 2 and 3 (each within the scatter of the next).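

Nitro in place of hydrogen on an aromatic carbon of the fused system gives a 1.7-fold higher number from compound 1 to compound 4 (0.23 log units; within the scatter) in this assay, so this ring position takes a group of three heavy atoms with no change beyond the scatter. The amide nitrogen behaves differently, with benzyl there giving an 8.5-fold higher number from compound 1 to compound 2 (0.93 log units; beyond the scatter) and a step beyond the scatter. Among these compounds, this is the first single-place reading on the fused ring, which compound 3 could not provide, as it differs from compound 1 in two places. No evidence at hand bears on why the position responds in this way.

As far as these compounds go, whether an amine or a carboxylic acid on the same carbon would also stay within the scatter remains open. So does whether nitro would read the same way on the other carbons of that ring.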